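The source may hold more compounds than are shown below. What is called first, only, known or untested is meant among the compounds shown, and "the series" means these compounds.

Compound 1 `O=C(O)CCCCCCCCCCCCCCCOc1ccc2c(=O)c(-c3ccc(O)cc3)coc2c1`: > 9000 nM
Compound 2 `CCOc1ccc2c(=O)c(-c3ccc(O)cc3)coc2c1`: 80 nM

In an assay (Cricetulus griseus) for inhibition of aldehyde dehydrogenase, mitochondrial (Homo sapiens) (on this read-out lower numbers stand for stronger inhibition and higher numbers for weaker inhibition), compound 1 reaches only the limit of the measurement, > 9000 nM. Compound 2 gives 80 nM in this assay, the sole actual number among the two results shown. Compound 3 `C=CCCCCOc1ccc2c(=O)c(-c3ccc(O)cc3)coc2c1` carries but-3-en-1-yl in place of hydrogen on a saturated chain carbon, two bonds along the chain from an oxygen on an aromatic ring. No step between measured compounds is shown, so the pair only tells that a long acid-bearing chain sits at the limit while the short ethoxy gives a number. The expected step, a 3.8-fold higher number from compound 2 to compound 3 (0.57 log units; beyond the scatter), is a loss beyond the scatter. Compound 3 is estimated at 300 nM, within 80 nM to 1500 nM.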

Compound 3, half-maximal inhibitory concentration: 150 nM
For compound 3 the middle estimate is 2.0-fold (0.30 log units) above the measured one; measured number inside the range.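

In this assay, putting but-3-en-1-yl on this saturated chain carbon gives a 1.9-fold higher number from compound 2 to compound 3 (0.27 log units; within the scatter), so these 4 extra carbon atoms produce no change that can be told from the scatter. The ethoxy group is therefore not the only chain at this position that gives an actual number, since the hex-5-en-1-yl chain of compound 3 does too. Compound 1 remains a limit, not a number: the limit of > 9000 nM in this assay, at which 1 of the 3 values shown sits.

Open, as far as these compounds go, is whether a saturated hexyl chain would read like the hex-5-en-1-yl chain. Also open, from the compounds shown here alone, is whether a carboxylic acid on a short chain would give a number.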